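Swapping Pyridin-4-yl for 4-Methylphenyl on a Shared Core

The source may report more compounds than this note shows. Statements on the series, on what has been measured and on what is new or still open speak of the compounds shown alone.

Compound 1 `O=C1/C(=C/c2ccncc2)C(c2ccccc2)Oc2ccccc21` stands at the higher of the two numbers recorded so far: in a functional assay on NALM-6 cells (Homo sapiens) for cytotoxicity, read by MTT assay, with a stated time of 46 h (a higher number here means a weaker inhibitor, a lower number a stronger inhibitor), compound 1 gives 1600 nM. Going by the values given here, its only neighbour is compound 2 `O=C1/C(=C\c2ccncc2)C(c2ccccc2)Oc2ccccc21`, which in this assay gives 700 nM. The two share every atom and bond and differ only in the drawn geometry of the exocyclic double bond, a 2.3-fold lower number from compound 1 to compound 2 (0.36 log units; beyond the scatter); the pair is recorded as one (the fact that one of compounds 1 and 2 is drawn with a defined configuration and the other without, at the place where they differ), so that step speaks to configuration and to nothing else.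

Compound 3 `Cc1ccc(/C=C2/C(=O)c3ccccc3OC2c2ccccc2)cc1` keeps the geometry of compound 1 and alters the aryl group instead: 4-methylphenyl in place of pyridin-4-yl on a double-bonded chain carbon bound to a double-bonded ring carbon. Among the compounds with values here, no measured step touches this position; the single known step, from compound 1 to compound 2, concerns the double bond and leaves the aryl group untouched. With nothing comparable to lean on, the expectation for compound 3 in this assay is a step that stays within the scatter, carried with a wide range. The estimate for compound 3 is 1500 nM, between 400 nM and 6000 nM. The step this estimate expects is a 1.1-fold lower number from compound 1 to compound 3 (0.03 log units; within the scatter).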

Compound 3, half-maximal inhibitory concentration: 51400 nM
Beside the measured number, compound 3's estimate is 34-fold (1.53 log units) below it; the measured number lies above the stated range.
By their numbers in this assay, from the lowest: compound 2; then compound 1; then compound 3.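

In this assay, the aryl group on the double-bonded chain carbon proves far from neutral: 4-methylphenyl in place of pyridin-4-yl brings a 32-fold higher number from compound 1 to compound 3 (1.51 log units; beyond the scatter), a large step, whereas the change in double-bond geometry brought only the modest 2.3-fold lower number from compound 1 to compound 2 (0.36 log units; beyond the scatter). Among these three compounds, the swap at this position therefore moves the number much further than the change of geometry does, and it shows that the aryl group is not a freely exchangeable part of the shared core. Nothing measured on either group bears on this step, and its size remains unexplained.

The compounds shown leave open whether the loss of the ring nitrogen or the arrival of the methyl carries the step, a question that an unsubstituted phenyl group could help to separate. They also leave open whether a step of this size would recur with the double-bond geometry of compound 2, and how a phenyl group carrying an amine would behave at this position.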